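Pyrazole anilines: chloro to methyl on the aniline ring

The source may hold more compounds than are shown below. What is called first, only, known or untested is meant among the compounds shown, and "the series" means these compounds.

The series shares one core, shown in compound 1 `COc1ccc(-c2nn(-c3ccccc3)cc2CNc2ccc(C)cc2)cc1`, compound 2 `Cc1ccc(NCc2cn(-c3ccccc3)nc2-c2ccc(Cl)cc2)cc1` and compound 3 `Clc1ccc(NCc2cn(-c3ccccc3)nc2-c2ccc(Br)cc2)cc1`. In a functional assay on MCF7 cells (Homo sapiens) for antiproliferative activity, read by MTT assay, with a stated time of 48 h (on this read-out higher numbers stand for weaker inhibition and lower numbers for stronger inhibition), compound 1 gives 8160 nM, compound 2 gives 3110 nM and compound 3 gives 4150 nM. Compound 3 stands second highest of the three numbers; against compound 2 the gap is within the scatter, and against compound 1 it is also within the scatter, so the three values are not ordered with confidence.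

Among the compounds with values here, the only single-point step so far is a 2.6-fold lower number from compound 1 to compound 2 (0.42 log units; beyond the scatter), chloro in place of methoxy on an aromatic carbon. Compound 4 `Cc1ccc(NCc2cn(-c3ccccc3)nc2-c2ccc(Br)cc2)cc1` differs from compound 3 by methyl in place of chloro on an aromatic carbon. Within the data shown here, this is a different exchange from the one measured, and on a different aromatic carbon, so no step bears on it directly. Compound 2 and compound 3 differ in two places and their values sit within the scatter of each other, which gives no sign that halogen and methyl on this ring separate the numbers.

For compound 4 the expected step is a 1.2-fold lower number from compound 3 to compound 4 (0.07 log units; within the scatter), within the scatter. Compound 4 is therefore estimated at 3500 nM, with a range from 1800 nM to 7000 nM.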

Compound 4, half-maximal inhibitory concentration: 5380 nM
Compound 4: the middle estimate sits 1.5-fold (0.19 log units) below what was measured; the range from low to high includes it.
By their numbers in this assay, from the lowest: compounds 2, 3, 4 and 1 (each within the scatter of the next, the first and the last beyond it).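

In this assay, within the data shown here, the change from 4-chlorophenyl to 4-methylphenyl gives the first direct reading at this position (a 1.3-fold higher number from compound 3 to compound 4 (0.11 log units; within the scatter)), and it does not separate chloro from methyl. Compound 4 also adds two readings at the aromatic carbon that carries bromo, chloro or methoxy: bromo in place of chloro (a 1.7-fold higher number from compound 2 to compound 4 (0.24 log units; within the scatter)) and bromo in place of methoxy (a 1.5-fold lower number from compound 1 to compound 4 (0.18 log units; within the scatter)) both stay within the scatter, so of the exchanges at that carbon only chloro in place of methoxy (a 2.6-fold lower number from compound 1 to compound 2 (0.42 log units; beyond the scatter)) lies beyond it. No measurement available here accounts for any of these steps.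

Still open, on these data alone, is whether an amine, a carboxylic acid or a longer chain in place of methyl on the 4-methylphenyl ring would shift the number beyond the scatter, since chloro and methyl alone span too little to show how far this position responds. Also open, as far as these compounds go, is how the series responds to a fluoro or a hydroxyl group on the phenyl that stays unchanged across all four compounds.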